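Phenyl in Place of Pyrazin-2-yl: An Expected Small Shift

The source may report more compounds than this note shows. Statements on the series, on what has been measured and on what is new or still open speak of the compounds shown alone.

Going by the values given here, compound 2 `Cc1nn(-c2nc(-c3ccc(Cl)c(Cl)c3)c(SC(C)C)s2)c(C(=O)O)c1-c1cnccn1` gives 14000 nM in a functional assay on BJAB cells (Homo sapiens) for antiproliferative activity, with a stated time of 4 days (on this read-out higher numbers stand for an effect only at larger amounts of compound and lower numbers for an effect already at smaller amounts), the lowest of the three numbers measured so far. Compound 1 `Cc1nn(-c2nc(-c3ccc(Cl)c(Cl)c3)c(SC(C)C)s2)c(C(=O)O)c1-c1cccc(C(F)(F)F)c1` gives 22000 nM in this assay , and the step of a 1.6-fold lower number from compound 1 to compound 2 (0.20 log units; within the scatter) lies within the scatter. Compound 3 `COC(=O)c1c(Cc2ccccc2[N+](=O)[O-])c(C)nn1-c1nc(-c2ccc(Cl)c(Cl)c2)c(SC(C)C)s1` gives 93000 nM in this assay , a number beyond the scatter from that of compound 2. Compound 4 `Cc1nn(-c2nc(-c3ccc(Cl)c(Cl)c3)c(SC(C)C)s2)c(C(=O)O)c1-c1ccccc1` differs from compound 2 by phenyl in place of pyrazin-2-yl on an aromatic carbon. Among the compounds with values here, no measured step swaps pyrazin-2-yl for phenyl, but the one exchange of the group at this position, from compound 1 to compound 2, changed little, so a step of no more than the scatter is expected, with the number for compound 4 likely close to those of compounds 1 and 2. Compound 4 is therefore estimated at 18000 nM, within 8000 nM to 45000 nM, an expected step of a 1.3-fold higher number from compound 2 to compound 4 (0.11 log units; within the scatter).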

Compound 4, half-maximal effective concentration: 3000 nM
For compound 4 the middle estimate is 6.0-fold (0.78 log units) above the measured one, outside the stated range (below it).
By their numbers in this assay, from the lowest: compound 4; then compounds 2 and 1 (each within the scatter of the next); then compound 3.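

Going by these compounds alone, the position proved more sensitive than the earlier compounds suggested: in this assay, replacing pyrazin-2-yl with phenyl gives a 4.7-fold lower number from compound 2 to compound 4 (0.67 log units; beyond the scatter), and replacing trifluoromethyl with hydrogen on the phenyl ring gives a 7.3-fold lower number from compound 1 to compound 4 (0.87 log units; beyond the scatter). Both groups therefore separate from plain phenyl, even though the step of a 1.6-fold lower number from compound 1 to compound 2 (0.20 log units; within the scatter) showed no separation between them. Nothing available here accounts for these differences. The compounds shown leave open how a phenyl ring bearing an amine, a methoxy group or a fluorine would read. They also leave open whether a saturated ring such as cyclohexyl would match phenyl here.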